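Lengthening the Chain Beyond a Saturated Ring

The source may report more compounds than this note shows. Statements on the series, on what has been measured and on what is new or still open speak of the compounds shown alone.

Compound 1, `CO[C@H]1CC[C@@H](CNc2cc(NCc3cnccc3C(F)(F)F)ncc2C#N)CC1`: 70 nM
Compound 2, `CO[C@H]1CC[C@H](CNc2cc(NCc3cnccc3C(F)(F)F)ncc2C#N)CC1`: 330 nM
Compound 3, `N#Cc1cnc(NCc2cnccc2C(F)(F)F)cc1NCC1CCOCC1`: 400 nM

These values come from an assay on isolated protein for inhibition of protein kinase C theta type (Homo sapiens), read by TR-FRET, with a stated time of 2 h; a higher number here means a weaker inhibitor, a lower number a stronger inhibitor. Compound 3 has the highest number of the three: a 1.2-fold higher number from compound 2 to compound 3 (0.08 log units; within the scatter), whereas a 5.7-fold higher number from compound 1 to compound 3 (0.76 log units; beyond the scatter). Compound 4, `N#Cc1cnc(NCc2cnccc2C(F)(F)F)cc1NCCC1CCOCC1`, is not yet measured; it differs from compound 3 by (oxan-4-yl)methyl in place of oxan-4-yl on a saturated chain carbon bound to a nitrogen on an aromatic ring. For the measured compounds named here, none of the measured steps lengthens a chain: a 4.7-fold higher number from compound 1 to compound 2 (0.67 log units; beyond the scatter) rests only on (the fact that compounds 1 and 2 differ only in the configuration as drawn), and the other two steps swap one saturated ring for another. Without a comparable step, no change beyond the scatter is expected. Compound 4 is therefore estimated at 400 nM, with a range from 130 nM to 1200 nM. This expectation means no change at the digits printed from compound 3 to compound 4 (within the scatter).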

Compound 4, half-maximal inhibitory concentration: 1200 nM
The estimate for compound 4 lay 3.0-fold (0.48 log units) below the measured number; the measured number falls inside the stated range.
By their numbers in this assay, from the lowest: compound 1; then compounds 2 and 3 (each within the scatter of the next); then compound 4.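

In this assay, the first chain lengthening seen at this position, from (oxan-4-yl)methyl to 2-(oxan-4-yl)ethyl, gives a 3.0-fold higher number from compound 3 to compound 4 (0.48 log units; beyond the scatter), so the added carbon weakens inhibition. The longer chain also does not match either 4-methoxycyclohexyl compound, with a 3.6-fold higher number from compound 2 to compound 4 (0.56 log units; beyond the scatter) and a 17-fold higher number from compound 1 to compound 4 (1.23 log units; beyond the scatter). Nothing available bears on the cause of this loss. Still open, on these data alone, is whether a 3-(oxan-4-yl)propyl chain would weaken inhibition further, and whether a 2-(4-methoxycyclohexyl)ethyl group would lose as much in either drawn configuration.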